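Cyclopropyl-substituted purine acetamides with amino acid ends

This account rests on a few compounds, and the source may have more. Where it says the series, first, only, none or still open, it means among the compounds named here.

Measured compounds:
- compound 1 `O=C(O)[C@@H]1CCCN1C(=O)CN(c1nc(Cl)nc2[nH]cnc12)C1CC1` — 34.9%
- compound 2 `O=C(OCc1ccccc1)[C@@H]1CCCN1C(=O)CN(c1nc(Cl)nc2[nH]cnc12)C1CC1` — 34.4%
- compound 3 `O=C(CN(c1nc(Cl)nc2[nH]cnc12)C1CC1)N[C@@H](CCC(=O)OCc1ccccc1)C(=O)OCc1ccccc1` — 53.7%

In a functional assay on the whole organism (Tail, strain ICR) with Mus musculus as the target, in the tail flick test, with a stated time of 60 min, at a dose of 25 umol/kg by the oral route (on this read-out lower numbers stand for a weaker effect and higher numbers for a stronger effect at the one dose given), compound 1 gives 34.9% and stands second highest of the three numbers; compound 2 is nearest, with a number 0.5 percentage points lower from compound 1 to compound 2 (within the scatter), and compound 3, with 53.7%, is the furthest and lies beyond the scatter from compound 1. For the measured compounds named here, the single step recorded, benzyl in place of hydrogen on an oxygen next to a carbonyl group, is within the scatter, so the acid and its ester behave alike here. Compound 3 differs from compound 1 in more than one place, so its value alone is noted.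

Compound 4 `CC(C)[C@H](NC(=O)CN(c1nc(Cl)nc2[nH]cnc12)C1CC1)C(=O)O` keeps the shared core and the acid and changes the amino acid part: (1-carboxy-2-methylpropyl)amino in place of 2-carboxypyrrolidin-1-yl on a carbonyl carbon. Going by the values given here, no measured step bears directly on this change; the only recorded step concerns the ester and is within the scatter, and compound 3, a different open-chain amino acid, gives 53.7%. The change is therefore expected to give a small step, a number 5.1 percentage points higher from compound 1 to compound 4 (within the scatter), at most toward a slightly stronger effect, because compound 3 with 53.7% shows an open-chain amino acid can sit higher. For compound 4 the estimate in this assay is 40%, with a range from 24% to 56%.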

Compound 4, a percentage reported as activity, at one dose (the size of the read-out at that dose, not a potency): 38.8%
Beside the measured number, compound 4's estimate is 1.2 percentage points above it, within the range that was stated.
By their numbers in this assay, from the lowest: compounds 2, 1 and 4 (each within the scatter of the next); then compound 3.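

At the carbonyl carbon, (1-carboxy-2-methylpropyl)amino in place of 2-carboxypyrrolidin-1-yl gives a number 3.9 percentage points higher from compound 1 to compound 4 (within the scatter) in this assay. The earlier step touched only the ester, whereas this one changes the amino acid part itself: an open-chain group and the five-membered non-aromatic ring read alike at this place, so that ring is not required for an effect of this size at this dose. Nothing measured accounts for this result.

Open, on these data alone, is whether a primary amine or a longer chain on the open-chain amino acid would move the read-out, and whether a benzyl ester of compound 4 would read alike with its acid. The number of compound 3 stays unassigned to any single feature, since compound 3 differs from compound 1 in more than one place.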